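Swapping fluoro for methyl on a flavone ester

This account rests on a few compounds, and the source may have more. Where it says the series, first, only, none or still open, it means among the compounds named here.

Measured so far:
Compound 1, `COC(=O)c1c(F)cccc1OC(=O)COc1cc(O)c2c(=O)cc(-c3ccccc3)oc2c1`, gives 40300 nM.
Compound 2, `COC(=O)c1cc(F)ccc1OC(=O)COc1cc(O)c2c(=O)cc(-c3ccccc3)oc2c1`, gives 6820 nM.

Both compounds share the same core and differ only in the ring attached to the oxygen next to a carbonyl group. Among the measured compounds shown here, in a functional assay on cells (T-cell, Mus musculus, strain BALB/c) for inhibition, read by MTT assay, with a stated time of 72 h (on this read-out higher numbers stand for weaker inhibition and lower numbers for stronger inhibition), compound 2 stands lowest of the two numbers; the one step measured, a 5.9-fold lower number from compound 1 to compound 2 (0.77 log units; beyond the scatter), shows that moving the fluorine on that ring matters.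

Compound 3, `COC(=O)c1cc(C)ccc1OC(=O)COc1cc(O)c2c(=O)cc(-c3ccccc3)oc2c1`, has not been measured. It differs from compound 2 by methyl in place of fluoro on an aromatic carbon.

For the measured compounds named here, no measured step covers a fluoro-to-methyl swap; the only step known concerns where the fluoro sits, not what replaces it, so it offers little guidance here. Going by the values given here, with no direct precedent, the expectation is a change no larger than the usual scatter, in either direction, and compound 3 is estimated at 7000 nM, ranging from 2500 nM to 20000 nM. This estimate means a step of a 1.0-fold higher number from compound 2 to compound 3 (0.01 log units; within the scatter), which is expected to stay close to compound 2.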

Compound 3, half-maximal inhibitory concentration: 25700 nM
For compound 3 the middle estimate is 3.7-fold (0.56 log units) below the measured one; measured number outside the range, above it.
By their numbers in this assay, from the lowest: compound 2; then compounds 3 and 1 (each within the scatter of the next).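

In this assay, the swap of fluoro for methyl on this aromatic carbon, para to a large group, is not a neutral exchange of one heavy atom for another: the result is a 3.8-fold higher number from compound 2 to compound 3 (0.58 log units; beyond the scatter), so compound 2 keeps the lowest number of the three. The change also removes the whole advantage that compound 2 held over compound 1, as the comparison of the two weaker compounds gives a 1.6-fold lower number from compound 1 to compound 3 (0.20 log units; within the scatter), which leaves them indistinguishable on this read-out. No measurement available here explains why fluoro and methyl behave differently at this position.

With only two groups compared at this position, the compounds shown cannot say whether fluoro is especially favourable or methyl especially unfavourable, and a plain hydrogen, a chlorine, a methoxy group or an amine there would help to separate those two readings. On these data alone, it also remains open whether methyl would give a similar result on the ring carbon that carries the fluoro in compound 1.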